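Swapping phenyl for methyl on a second core

The source may report more compounds than this note shows. Statements on the series, on what has been measured and on what is new or still open speak of the compounds shown alone.

Of the compounds shown here, three have been measured in an assay on isolated protein for inhibition of protein kinase C zeta type (Homo sapiens), read by mobility shift assay, tested at 30 uM; on this read-out lower numbers stand for less inhibition and higher numbers for more inhibition at the one concentration tested (going by the name of the read-out). Compound 1 `Cc1cc2nn(-c3ccccc3)c(N)c2c(=O)[nH]1` gives -49%. Compound 2 `Nc1c2c(=O)[nH]c(-c3ccccc3)cc2nn1-c1ccccc1` gives -163%. Compound 3 `Cc1cc2nc(-c3ccccc3)nc(N)c2c(=O)[nH]1` gives -17%, the highest of the three numbers, and the difference between its core and the core of compound 2 is not broken down here.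

Compounds 2 and 1 differ in one place only, (methyl in place of phenyl on an aromatic carbon), and this change made the step of a number 114 percentage points higher from compound 2 to compound 1 (beyond the scatter).

Compound 4 `Cc1nc(N)c2c(=O)[nH]c(C)cc2n1` has not yet been measured. It differs from compound 3 by the same kind of change, (methyl in place of phenyl on an aromatic carbon). The change is not the same, since the surroundings differ: in compound 3 the carbon that carries the phenyl sits in a six-membered aromatic ring with 2 nitrogen, between two ring nitrogen atoms and meta to an amino group, whereas in compound 2 it sits in a ring with 1 nitrogen, next to the ring nitrogen and meta to a group of 1 heavy atom.

The same kind of change once made a step of a number 114 percentage points higher from compound 2 to compound 1 (beyond the scatter), so a rise is expected for compound 4 as well, though a smaller one, since compound 3 already gives -17% and this change occurs only twice among the compounds shown. The step from compound 3 to compound 4 is estimated at a number 27 percentage points higher from compound 3 to compound 4 (beyond the scatter). In this assay compound 4 is expected to give about 10%, with a likely range from -40% to 50%.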

Compound 4, a percentage reported as inhibition, at one concentration (the size of the read-out at that concentration, not a potency): 3%
Compound 4: middle estimate off by 7 percentage points, on the high side, within the range that was stated.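

On the core of compound 3, putting methyl in place of phenyl on an aromatic carbon gave a step of a number 20 percentage points higher from compound 3 to compound 4 (beyond the scatter) in this assay, which points the same way as the earlier step on the core of compound 1, a number 114 percentage points higher from compound 2 to compound 1 (beyond the scatter). The direction therefore carried over from one core to the other, but the size did not, and the two steps differ clearly: the same change on two cores in this assay, a number 114 percentage points higher (beyond the scatter) from compound 2 to compound 1 and a number 20 percentage points higher (beyond the scatter) from compound 3 to compound 4, 94 percentage points apart, beyond the scatter of two such steps These two pairs show that the surrounding core can strongly change how much this swap moves the number, but they do not show why it does so, whether the same direction would hold on a further core, or how potent any compound is, since each number comes from a single tested concentration.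

The compounds shown carry only phenyl or methyl on this aromatic carbon, so it remains open whether an ethyl group, a longer chain, an amine or a carboxylic acid there would raise the number further or lower it. From the compounds shown here alone, it also remains open whether any such group would behave alike on both cores, or would again give steps of very different size.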